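Hydroxy for Trifluoromethyl on the Anilide of Compound 1

The source may report more compounds than this note shows. Statements on the series, on what has been measured and on what is new or still open speak of the compounds shown alone.

Compound 1 `O=C(Nc1ccccc1C(F)(F)F)c1nccc2ccccc12` carries an amide-linked aromatic ring bearing trifluoromethyl. In a functional assay on NUGC-3 cells (Homo sapiens) for inhibition, read by sulforhodamine B assay, with a stated time of 48 h (a lower number here means a stronger inhibitor of growth, a higher number a weaker inhibitor of growth), compound 1 gives > 10000 nM, which is a limit of the assay and not a number. Compound 1 thus stands at the limit of > 10000 nM in this assay, at which 2 of the 3 values shown sit, and its place among the numbers shown cannot be fixed more closely than that.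

The two other measured compounds share a different, partly saturated core. Compound 2 `O=C(Nc1ccc(O)cc1)C1NCCc2ccccc21` carries hydroxy on its anilide ring, and in this assay compound 2 gives 4370 nM. Compound 3 `O=C(Nc1ccccc1O)C1NCCc2ccccc21` also carries hydroxy on its anilide ring; in this assay compound 3 gives > 10000 nM, again a limit and not a number.

Compound 4 `O=C(Nc1ccccc1O)c1nccc2ccccc12` is compound 1 with hydroxy in place of trifluoromethyl on an aromatic carbon, ortho to a large group. Going by the values given here, no measured pair isolates this change on either core. The expectation for the step that the limit leaves unreadable from compound 1 to compound 4 is none beyond the scatter, since compound 3, the hydroxy-bearing compound with a related amide, sits at the same limit as compound 1. Compound 4 is therefore estimated at 15000 nM, within 5000 nM to 50000 nM, and a limit rather than a number is the more likely report.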

Compound 4, concentration for 50% growth inhibition: > 10000 nM
Compound 4 ended at the assay's limit (the forecaster's own chance of this, stated with the estimate: 65%); the middle value lies beyond the limit too.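

No step from compound 1 to compound 4 can be read, because both are reported only as a limit of the assay and not as a number: the limit of > 10000 nM in this assay, at which 3 of the 4 values shown sit.

The compounds shown leave open whether hydroxy in place of trifluoromethyl on an aromatic carbon changes growth inhibition at all on the core of compound 1.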